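The source may hold more compounds than are shown below. What is called first, only, known or untested is meant among the compounds shown, and "the series" means these compounds.

For the measured compounds named here, compound 3 `CC1=CC[C@@H]([C@@](C)(O)CCCC(C)(C)NC(=S)N/N=C\c2ccc(O)cc2)CC1` stands second highest of the three numbers so far in a functional assay on K562 cells (Homo sapiens) for cytotoxicity, read by sulforhodamine B assay (on this read-out higher numbers stand for weaker inhibition of growth and lower numbers for stronger inhibition of growth), giving 31100 nM. Its nearest neighbour is compound 2 `COc1ccc(/C=N\NC(=S)NC(C)(C)CCC[C@](C)(O)[C@@H]2CC=C(C)CC2)cc1`, which gives 34900 nM; the two lie a 1.1-fold lower number from compound 2 to compound 3 (0.05 log units; within the scatter). The furthest is compound 1 `CC1=CC[C@@H]([C@@](C)(O)CCCC(C)(C)NC(=S)N/N=C\c2ccc(C)cc2)CC1`, which gives 7950 nM, and the steps of a 4.4-fold higher number from compound 1 to compound 2 (0.64 log units; beyond the scatter) and a 3.9-fold higher number from compound 1 to compound 3 (0.59 log units; beyond the scatter) show that changing the group on the aromatic ring moves the number by a modest amount.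

Compound 4 `CC1=CC[C@@H]([C@@](C)(O)CCCC(C)(C)NC(=S)N/N=C\c2ccccc2[N+](=O)[O-])CC1` differs from compound 3 by 2-nitrophenyl in place of 4-hydroxyphenyl on a carbon with a double bond to nitrogen. Going by the values given here, none of the measured steps carries a nitro group or a group at the 2-position of the ring, so they bear on this change only by showing that aromatic substituent swaps have stayed modest in size, in either direction. On that basis the step expected in this assay from compound 3 to compound 4 is small, a 2.1-fold lower number from compound 3 to compound 4 (0.32 log units; beyond the scatter), with wide uncertainty. Compound 4 is therefore estimated at 15000 nM, within a range of 4000 nM to 60000 nM.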

Compound 4, concentration for total growth inhibition: 7840 nM
Compound 4: the middle estimate sits 1.9-fold (0.28 log units) above what was measured; low and high end bracket the measured number.
By their numbers in this assay, from the lowest: compounds 4 and 1 (each within the scatter of the next); then compounds 3 and 2 (each within the scatter of the next).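

In this assay, the 2-nitrophenyl group on the carbon with a double bond to nitrogen shows that a ring carrying neither a methyl nor an oxygen-linked group in the 4-methylphenyl, 4-methoxyphenyl or 4-hydroxyphenyl manner can still match 4-methylphenyl, with a 1.0-fold lower number from compound 1 to compound 4 (0.01 log units; within the scatter). Set against the two oxygen-bearing groups, it gives a 4.0-fold lower number from compound 3 to compound 4 (0.60 log units; beyond the scatter) and a 4.5-fold lower number from compound 2 to compound 4 (0.65 log units; beyond the scatter), so the low and high levels seen earlier are not tied to the 4-methylphenyl group alone. Nothing measured here explains these differences.

The swap changes both the group and its place on the ring, so the shown compounds cannot separate the two. A 4-nitrophenyl or a 2-methylphenyl group would bear on that, and a 4-aminophenyl group would test a further nitrogen-bearing substituent.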